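A Pyridinyl Swap on the Carbonyl Carbon

A few compounds are considered here, and "the series" means these few. Any claim that something is new, unique, unknown or untested is made for them only; others in the source may bear on it.

In an ADME assay on HEK293 cells (Homo sapiens) for cytotoxicity, read by MTT assay, with a stated time of 24 h (a higher number here means a weaker inhibitor, a lower number a stronger inhibitor), compound 1 (`COC(=O)c1scc(-c2ccc(NC(=O)c3ccccn3)cc2)c1OC`) has no number to stand on, with "not determined" (no result reported) as its entry. Compound 2 (`COC(=O)c1scc(-c2ccc(NC(=O)c3cccc(C(F)(F)F)c3)cc2)c1OC`) shares that position, with "not determined" (no result reported) as its entry. Compound 3 (`COC(=O)c1scc(-c2ccc(NC(=O)c3cccc(I)c3)cc2)c1OC`) alone gives a number, at 42700 nM as its half-maximal inhibitory concentration.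

Compound 4 (`COC(=O)c1scc(-c2ccc(NC(=O)c3ccc(OC)nc3)cc2)c1OC`) keeps the shared core and differs from compound 1 at one place. The change 6-methoxypyridin-3-yl in place of pyridin-2-yl on a carbonyl carbon puts 6-methoxypyridin-3-yl in place of pyridin-2-yl on a carbonyl carbon.

Among the measured compounds shown here, no measured pair shows the size of such a step, so in this assay the expectation rests on compound 3 at 42700 nM, and no clear shift from it is expected in either direction. Compound 4 is expected at 40000 nM with an estimated range from 15000 nM to 100000 nM in this measurement.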

Compound 4, half-maximal inhibitory concentration: > 50000 nM
Compound 4: a limit, no number; the forecaster's own chance of this, stated with the estimate: 25%; middle value at least 1.2-fold (0.09 log units) away from the limit.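

In this assay, compound 4 gives > 50000 nM, which is a limit and not a number. Placing 6-methoxypyridin-3-yl in place of 3-iodophenyl on a carbonyl carbon gives an at least 1.1-fold higher number from compound 3 to compound 4 (0.06 log units; that floor lies within the scatter), so this first step at the position shows no change beyond the scatter, and its true size is not fixed. The reading is one-sided: the limit of > 50000 nM in this assay, at which 1 of the 4 values shown sits.

Going by these compounds, how far compound 4 lies from compound 3 stays open, and the step from compound 1 to compound 4 cannot be read. Also open, on these data alone, is what an amine or a carboxylic acid would give on this carbonyl carbon.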